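Pyridone variation on the isoxazole of a bile acid receptor series

A few compounds are considered here, and "the series" means these few. Any claim that something is new, unique, unknown or untested is made for them only; others in the source may bear on it.

Measured so far, in a functional assay for agonist activity at Bile acid receptor (Mus musculus), read by a luciferase reporter; a higher number here means that more compound is needed for the effect, a lower number that less compound is needed:
compound 1 `Cc1cc(OCc2c(-c3c(Cl)ccc(=O)n3C)noc2C(C)C)ccc1-c1ccc2c(C(=O)O)cn(C)c2c1` gives 4000 nM
compound 2 `Cc1cc(OCc2c(-c3[nH]c(=O)ccc3Cl)noc2C(C)C)ccc1-c1ccc2c(C(=O)O)cn(C)c2c1` gives 18000 nM
compound 3 `Cc1cc(OCc2c(-c3cc[nH]c(=O)c3Cl)noc2C(C)C)ccc1-c1ccc2c(C(=O)O)cn(C)c2c1` gives 7000 nM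

Compound 3 stands second highest of the three numbers; its nearest neighbour is compound 1, and the gap between them is within the scatter, so no order is read between those two. Compound 2 sits clearly higher: a 2.6-fold lower number from compound 2 to compound 3 (0.41 log units; beyond the scatter).

Compound 4 `Cc1cc(OCc2c(-c3c(Cl)cn(C)c(=O)c3Cl)noc2C(C)C)ccc1-c1ccc2c(C(=O)O)cn(C)c2c1` is not yet measured. Relative to compound 3 the change is a group of 10 heavy atoms (6 carbon, 1 nitrogen, 1 oxygen, 2 chlorine; one six-membered aromatic ring with 1 hetero atom) in place of a group of 8 heavy atoms (5 carbon, 1 nitrogen, 1 oxygen, 1 chlorine; one six-membered aromatic ring with 1 hetero atom), on an aromatic carbon.

Going by the values given here, only one measured step bears on part of this change. Hydrogen in place of methyl on the aromatic nitrogen gave a 4.5-fold higher number from compound 1 to compound 2 (0.65 log units; beyond the scatter), so the reverse direction, methyl on that nitrogen, is expected to lower the number. Among the compounds with values here, no measured pair speaks to the second chlorine on the ring. For compound 4 a modest lowering is therefore expected, a 2.8-fold lower number from compound 3 to compound 4 (0.45 log units; beyond the scatter), with wide uncertainty because only compound 1 and compound 2 inform it through a 4.5-fold higher number from compound 1 to compound 2 (0.65 log units; beyond the scatter). Compound 4 is expected to give about 2500 nM, between 800 nM and 8000 nM.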

Compound 4, half-maximal effective concentration: 11000 nM
Beside the measured number, compound 4's estimate is 4.4-fold (0.64 log units) below it; measured number above the stated range.
By their numbers in this assay, from the lowest: compounds 1, 3, 4 and 2 (each within the scatter of the next, the first and the last beyond it).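

In this assay, the entering group, with 2 chlorine and 0 hydrogen-bond donors, does not separate compound 4 from the two nearest compounds: a 1.6-fold higher number from compound 3 to compound 4 (0.20 log units; within the scatter) and a 1.6-fold lower number from compound 2 to compound 4 (0.21 log units; within the scatter) both lie within the scatter, so no order can be read there. A gap appears only against compound 1, a 2.8-fold higher number from compound 1 to compound 4 (0.44 log units; beyond the scatter), so the lower number that went with methyl on the aromatic nitrogen of compound 1 does not reappear in compound 4, where methyl comes together with a second chlorine on a differently arranged pyridone. No measured evidence on these compounds accounts for this result.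

Which part of the change, the methyl or the second chlorine, sets the number for compound 4 stays open. Also open, on these data alone, is how a fluorine or an amine in place of a chlorine on the pyridone would read in this assay.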